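Swapping the aryl group on the urea nitrogen

The source may hold more compounds than are shown below. What is called first, only, known or untested is meant among the compounds shown, and "the series" means these compounds.

Compound 2 `Cc1ccc(NC(=O)Nc2cc(C(C)(C)C)nn2-c2ccccc2)cc1` and compound 1 `Cc1ccc(F)cc1NC(=O)Nc1cc(C(C)(C)C)nn1-c1ccccc1` share one core and differ only in the aryl group attached to one urea nitrogen. In an assay on isolated protein for inhibition of Ephrin type-A receptor 2 (Homo sapiens), read by thermal shift assay, tested at 10 uM (on this read-out higher numbers stand for stronger stabilisation of the target against heat and lower numbers for weaker stabilisation of the target), compound 1 gives 1.6 degrees C, and in the same assay compound 2 gives 1.7 degrees C; the two numbers sit within the scatter of each other, so neither stands apart, and the step of a number 0.10 degrees C higher from compound 1 to compound 2 (within the scatter) shows that exchanging one substituted phenyl for another at this nitrogen changed little.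

Compound 3 `CC(C)(C)c1cc(NC(=O)Nc2cc(F)cc(F)c2)n(-c2ccccc2)n1` has not yet been measured. It differs from compound 2 in one place: 3,5-difluorophenyl in place of 4-methylphenyl on an amide-type nitrogen. Going by the values given here, the only measured step that bears on this position, from compound 1 to compound 2 a number 0.10 degrees C higher from compound 1 to compound 2 (within the scatter), stayed within the scatter, and it swapped a fluorine-bearing phenyl for a methyl-bearing one; the present change goes the other way, to a phenyl carrying two fluorines. On that single precedent, a step of no more than the scatter in this assay is expected, in no clear direction, so the expected step of a number 0.20 degrees C lower from compound 2 to compound 3 (within the scatter) is small. For compound 3 the expected shift is 1.5 degrees C, with a range from 0.3 degrees C to 2.7 degrees C.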

Compound 3, shift of the target's melting temperature: 2.7 degrees C
For compound 3 the middle estimate is 1.2 degrees C below the measured one, within the range that was stated.
By their numbers in this assay, from the lowest: compounds 1, 2 and 3 (each within the scatter of the next, the first and the last beyond it).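

Going by these compounds alone, at this urea nitrogen the aryl group is not fully interchangeable: the step of a number 1.1 degrees C higher from compound 1 to compound 3 (beyond the scatter) in this assay is the first at this position to pass the scatter, although it is only modest. The step of a number 1.0 degrees C higher from compound 2 to compound 3 (within the scatter) stays within the scatter, so the 3,5-difluorophenyl group stands apart from the 5-fluoro-2-methylphenyl group but not from the 4-methylphenyl group, and the three compounds therefore do not form a clear ranking of these aryl groups. No measurement at hand gives a reason for the one difference that passes the scatter.

On these data alone, it remains open whether both fluorines matter, which a phenyl group with a single fluorine or with no substituent at all could test, and whether a chlorine, a methoxy group, an amine or a carboxylic acid on this ring would read any differently. The shared core is also the same in all three compounds, so these results say nothing about how changes elsewhere in the molecule would affect the read-out.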